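Replacing fluoro with methyl in compound 2

The compounds below may be only part of what the source reports. "The series", "measured", "known", "first", "only" and "open" are said of these compounds alone.

Of the compounds shown here, three sharing one core have been read in a physicochemical assay for lipophilicity, read by HPLC, at pH 7.4; on this read-out higher numbers stand for higher lipophilicity and lower numbers for lower lipophilicity. Compound 1 `O=C(Nc1ccc(F)c(-c2nc3ncccc3o2)c1)c1cnco1` gives 1.7, compound 2 `O=C(Nc1ccc(F)c(-c2nc3ncccc3o2)c1)c1ccoc1` gives 2.4 and compound 3 `Cc1ccoc1C(=O)Nc1ccc(F)c(-c2nc3ncccc3o2)c1` gives 2.9, which leaves compound 2 second highest of the three. Compound 4 `Cc1ccc(NC(=O)c2ccoc2)cc1-c1nc2ncccc2o1` keeps the furan-3-yl group of compound 2 and differs from it in one place: methyl in place of fluoro on an aromatic carbon. This is methyl in place of fluoro on an aromatic carbon, para to the ((furan-3-yl)carbonyl)amino group.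

For the measured compounds named here, no measured step touches that carbon, since all three change the group on the carbonyl carbon. The data show a number 0.70 log units higher from compound 1 to compound 2 (beyond the scatter) and a number 1.20 log units higher from compound 1 to compound 3 (beyond the scatter), the second being the largest. The closest guide is a number 0.50 log units higher from compound 2 to compound 3 (beyond the scatter), where 3-methylfuran-2-yl replaces furan-3-yl, and it bears on the change only indirectly. On that weak footing, an upward step is expected, a number 0.40 log units higher from compound 2 to compound 4 (beyond the scatter). The estimate for compound 4 is 2.8, with an expected range from 2.4 to 3.2.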

Compound 4, distribution coefficient: 2.7
Beside the measured number, compound 4's estimate is 0.10 log units above it; measured number inside the range.
By their numbers in this assay, from the lowest: compound 1; then compounds 2, 4 and 3 (each within the scatter of the next, the first and the last beyond it).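

In this assay, methyl in place of fluoro on this aromatic carbon, para to the ((furan-3-yl)carbonyl)amino group, gives a number 0.30 log units higher from compound 2 to compound 4 (within the scatter), so this read-out does not separate the two compounds. For the compounds shown here, this is the first reading at this position: all the earlier steps changed the group on the carbonyl carbon and all lay beyond the scatter, whereas this exchange of one heavy atom for another does not. Nothing in the data shown gives a cause for this result.

On these data alone, whether a methoxy group or an amine on this same carbon would give a step beyond the scatter stays open. So does whether methyl in place of fluoro reads the same with 1,3-oxazol-5-yl or 3-methylfuran-2-yl on the carbonyl carbon.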